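Butyl in Place of a Piperidine Ring: Cytotoxicity Outlook

The source may hold more compounds than are shown below. What is called first, only, known or untested is meant among the compounds shown, and "the series" means these compounds.

Three analogues sharing one core have been examined in an ADME assay on Huh-7 cells (Homo sapiens) for cytotoxicity; a higher number here means that more compound is tolerated, a lower number that less compound is tolerated. Compound 1 `Cc1ccccc1-c1nn(-c2ccc(F)cc2F)cc1CNCCN1CCN(C)CC1` reaches only the assay limit there, at > 20000 nM. Compound 2 `CCN(CC)CCCNCc1cn(-c2ccc(F)cc2F)nc1-c1ccccc1C` likewise stops at the limit, giving > 20000 nM in this assay. Compound 3 `CCCN1CCC(CNCc2cn(-c3ccc(F)cc3F)nc2-c2ccccc2C)CC1` also sits at a limit, with > 20000 nM in this assay. With three limits and no numbers, the steps among them remain unreadable: a step that the two limits leave unreadable from compound 1 to compound 2, a step that the two limits leave unreadable from compound 1 to compound 3 and a step that the two limits leave unreadable from compound 2 to compound 3. What the measured set does show is the limit of > 20000 nM in this assay, at which 3 of the 3 values shown sit.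

Compound 4 `CCCCCNCc1cn(-c2ccc(F)cc2F)nc1-c1ccccc1C` is the next member, not yet measured. It differs from compound 3 by butyl in place of 1-propylpiperidin-4-yl on a saturated chain carbon bound to an amine nitrogen. The measured steps that bear on this change are those among compounds 1, 2 and 3, each of which exchanged one amine-bearing group for another and stayed at the limit in every case; none yielded a number from which a size could be taken. The step expected from this change is therefore a step that the limit leaves unreadable from compound 3 to compound 4, meaning no movement beyond the scatter that could be read against the limit. Compound 4 is estimated at 25000 nM in this assay, within 10000 nM to 60000 nM, and is expected most likely to be reported as a limit as well.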

Compound 4, half-maximal cytotoxic concentration: 17000 nM
Beside the measured number, compound 4's estimate is 1.5-fold (0.17 log units) above it; measured number inside the range.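

For the compounds shown here, compound 4 gives the only true number among the four compounds in this assay, so butyl in place of 1-propylpiperidin-4-yl on a saturated chain carbon bound to an amine nitrogen now has a readable floor: an at least 1.1-fold lower number from compound 3 to compound 4 (0.07 log units; that floor lies within the scatter). The two other comparisons now have floors as well, an at least 1.1-fold lower number from compound 2 to compound 4 (0.07 log units; that floor lies within the scatter) and an at least 1.1-fold lower number from compound 1 to compound 4 (0.07 log units; that floor lies within the scatter), and here too the entering chain is free of the nitrogen carried by the group it replaces. These floors say little about the real size of the steps because the other three compounds remain limits: the limit of > 20000 nM in this assay, at which 3 of the 4 values shown sit.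

On these data alone, the steps among compound 1, compound 2 and compound 3 still cannot be read, and how far any of these three lies from compound 4 remains unknown. The compounds shown also leave open whether the number for compound 4 would move with a longer chain such as hexyl, or with a carboxylic acid or a terminal amine at the end of the butyl.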